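The source may hold more compounds than are shown below. What is called first, only, known or untested is meant among the compounds shown, and "the series" means these compounds.

Compound 1 `N#CC1(NC(=O)[C@@H]2C[C@@H](S(=O)(=O)c3ccccc3)C[C@H]2C(=O)N2CCOCC2)CC1` gives the lowest number of the two measured in a functional assay on A20 cells (Mus musculus) for inhibition, with stated times of 1 h, 16 h and 24 h (on this read-out higher numbers stand for weaker inhibition and lower numbers for stronger inhibition), compound 1 reading 12 nM. Compound 2 `N#CC1(NC(=O)[C@@H]2C[C@@H](S(=O)(=O)c3ccccc3)C[C@H]2C(=O)N2CCS(=O)(=O)CC2)CC1` gives 816 nM. Compound 3 `N#CC1(NC(=O)[C@@H]2C[C@@H](S(=O)(=O)c3ccccc3)C[C@H]2C(=O)N2CCCC2)CC1` is made from compound 1 by one change: pyrrolidin-1-yl in place of morpholin-4-yl on a carbonyl carbon. Going by the values given here, the only measured step, a 68-fold higher number from compound 1 to compound 2 (1.83 log units; beyond the scatter), also replaced the morpholin-4-yl but with 1,1-dioxothiomorpholin-4-yl, a different group, so it bears only loosely on this change. A moderate weakening beyond the scatter is expected, a 2.5-fold higher number from compound 1 to compound 3 (0.40 log units; beyond the scatter). Compound 3 is therefore estimated at 30 nM, with a range from 6 nM to 150 nM.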

Compound 3, half-maximal inhibitory concentration: 29 nM
Beside the measured number, compound 3's estimate is 1.0-fold (0.01 log units) above it, within the range that was stated.
By their numbers in this assay, from the lowest: compound 1; then compound 3; then compound 2.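

In this assay, replacing morpholin-4-yl with pyrrolidin-1-yl on the carbonyl carbon gives only a modest change, a 2.4-fold higher number from compound 1 to compound 3 (0.38 log units; beyond the scatter), so a low number at this position survives without the ring oxygen of morpholin-4-yl. The same position responds far more strongly to the ring in compound 2, as a 28-fold lower number from compound 2 to compound 3 (1.45 log units; beyond the scatter) shows, so the ring placed here matters greatly. No measurement shown here explains either step. Going by these compounds, whether piperidin-1-yl or an open-chain dimethylamino group on this carbonyl carbon would keep the number low remains open.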